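The source may report more compounds than this note shows. Statements on the series, on what has been measured and on what is new or still open speak of the compounds shown alone.

Among the compounds with values here, in a functional assay, read by fluorescence and spectrophotometry, with a stated time of 1 h (a higher number here means that more compound is needed for the effect, a lower number that less compound is needed), compound 1 `O=S(=O)(/C=C/c1ccc(O)c(O)c1)CCCCCCCCO` gives 6700 nM, the lowest of the two numbers so far, though its companion compound 2 `CC(C)(C)OC(=O)N1CCCC1CS(=O)(=O)/C=C/c1ccc(O)c(O)c1` gives 7100 nM, which lies within the scatter of that figure. Compound 3 `O=S(=O)(/C=C/c1ccc(O)c(O)c1)CCCC1CCCCC1` has not yet been measured in this assay. Against compound 1 it differs in one place: cyclohexyl in place of 5-hydroxypentyl on a saturated chain carbon, three bonds along the chain from a sulfonyl sulfur. Within the data shown here, with no step of this kind measured among the compounds, the account can only expect the step of a 1.3-fold lower number from compound 1 to compound 3 (0.13 log units; within the scatter) to stay modest, with no clear direction beyond the scatter. On that basis compound 3 is estimated at 5000 nM, within a range from 1500 nM to 20000 nM.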

Compound 3, half-maximal effective concentration: 7900 nM
Estimate against measurement, compound 3: 1.6-fold (0.20 log units) below; the measured number falls inside the stated range.
By their numbers in this assay, from the lowest: compounds 1, 2 and 3 (each within the scatter of the next).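

In this assay, cyclohexyl in place of 5-hydroxypentyl gives a 1.2-fold higher number from compound 1 to compound 3 (0.07 log units; within the scatter). At this place on the chain, then, a six-membered carbon ring can stand in for an open chain, and the hydrogen-bond donor and acceptor of 5-hydroxypentyl can go, without a change beyond the scatter. Nothing available accounts for this result. Going by these compounds, whether an amine or a carboxylic acid here would move the number beyond the scatter stays open. So does the outcome for a phenyl ring or a longer chain.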